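Changing the basic amine at the end of the chain

A few compounds are considered here, and "the series" means these few. Any claim that something is new, unique, unknown or untested is made for them only; others in the source may bear on it.

Measured so far in a functional assay on MCF7 cells (Homo sapiens) for antiproliferative activity, read by MTT assay, with a stated time of 72 h; on this read-out lower numbers stand for stronger inhibition and higher numbers for weaker inhibition:
Compound 1 `CCN(CC)CCCOc1cc2ncnc(Nc3ccc(C#N)cc3)c2cc1OC`: > 100000 nM, a limit of the assay.
Compound 2 `COc1cc2c(Nc3ccc(C#N)cc3)ncnc2cc1OCCCN(C)Cc1ccccc1`: > 100000 nM, also a limit.
Compound 3 `COc1cc2c(Nc3ccc(C#N)cc3)ncnc2cc1OCCCN1CCC(c2ccccc2)CC1`: 9800 nM.

Compound 2 thus stands not at a number but at a limit, shared with one other value (the limit of > 100000 nM in this assay, at which 2 of the 3 values shown sit). Compound 4 `COc1cc2c(Nc3ccc(C#N)cc3)ncnc2cc1OCCCN1CCN(C)CC1` differs from compound 2 in one place: 4-methylpiperazin-1-yl in place of benzyl(methyl)amino on a saturated chain carbon, three bonds along the chain from an oxygen on an aromatic ring. Two measured steps start from compound 2: a step that the two limits leave unreadable from compound 1 to compound 2, and an at least 10-fold lower number from compound 2 to compound 3 (1.00 log units; beyond the scatter). Only the 4-phenylpiperidin-1-yl has so far given a readable number, so the 4-methylpiperazin-1-yl, lacking that aromatic ring, offers little to build on. Compound 4 is expected to stay near the weak end, with an at least 1.6-fold lower number from compound 2 to compound 4 (0.22 log units; that floor lies within the scatter). The estimate for compound 4 is 60000 nM, between 10000 nM and 300000 nM.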

Compound 4, half-maximal inhibitory concentration: 71100 nM
For compound 4 the middle estimate is 1.2-fold (0.07 log units) below the measured one; the range from low to high includes it.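

Compound 4 gives a number in this assay, so a ring amine without an aromatic ring can also leave the limit that compound 1 and compound 2 share: the limit of > 100000 nM in this assay, at which 2 of the 4 values shown sit.

Against those two compounds the change can be read only as a floor, an at least 1.4-fold lower number from compound 2 to compound 4 (0.14 log units; that floor lies within the scatter) and an at least 1.4-fold lower number from compound 1 to compound 4 (0.14 log units; that floor lies within the scatter), so no real gain can be claimed. Compound 3 remains ahead, with a 7.3-fold higher number from compound 3 to compound 4 (0.86 log units; beyond the scatter).

The compounds shown leave open whether that lead comes from the piperidine ring or from its phenyl group, a question that a plain piperidin-1-yl at the chain end would address.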